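The source may report more compounds than this note shows. Statements on the series, on what has been measured and on what is new or still open speak of the compounds shown alone.

Among the measured compounds shown here, in a functional assay on HL-60 cells (Homo sapiens) for antiproliferative activity, with a stated time of 72 h (on this read-out lower numbers stand for stronger inhibition and higher numbers for weaker inhibition), compound 1 `CCCCC#Cc1cc([C@@H]2O[C@H](CO)[C@@H](O)[C@H]2O)n2ncnc(N)c12` gives 400 nM and compound 2 `Nc1ncnn2c([C@@H]3O[C@H](CO)[C@@H](O)[C@H]3O)cc(-c3ccc(F)cc3)c12` gives 68300 nM as the higher of the two numbers so far. For the measured compounds named here, the one measured step is a 170-fold higher number from compound 1 to compound 2 (2.23 log units; beyond the scatter) with 4-fluorophenyl in place of hex-1-yn-1-yl on an aromatic carbon. Compound 3 `Nc1ncnn2c([C@@H]3O[C@H](CO)[C@@H](O)[C@H]3O)cc(-c3ccc(F)cc3F)c12` keeps the rest of compound 2 and differs by fluoro in place of hydrogen on an aromatic carbon so that 4-fluorophenyl becomes 2,4-difluorophenyl. This is fluoro in place of hydrogen on an aromatic carbon, ortho to a large group and meta to a fluoro group. Going by the values given here, the large measured step exchanged a whole group, so it bears only loosely on this smaller change, and no measured pair shows the change itself. No direction can be read from the data, and in this assay no step beyond the scatter is expected. The expectation therefore starts from compound 2 at 68300 nM and stays close to it. The estimated change is a 1.4-fold lower number from compound 2 to compound 3 (0.14 log units; within the scatter) and is expected to remain small. Compound 3 is expected at 50000 nM within an estimated range of 15000 nM to 120000 nM on this read-out.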

Compound 3, half-maximal inhibitory concentration: 99300 nM
Beside the measured number, compound 3's estimate is 2.0-fold (0.30 log units) below it; low and high end bracket the measured number.
By their numbers in this assay, from the lowest: compound 1; then compounds 2 and 3 (each within the scatter of the next).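

In this assay, among the compounds shown here, the fluoro group that enters on the aromatic carbon, ortho to a large group and meta to a fluoro group, turns 4-fluorophenyl into 2,4-difluorophenyl and gives a 1.5-fold higher number from compound 2 to compound 3 (0.16 log units; within the scatter), the first direct reading of this change, which shows that it leaves the number within the scatter. Replacing hex-1-yn-1-yl with 2,4-difluorophenyl gives a 250-fold higher number from compound 1 to compound 3 (2.39 log units; beyond the scatter), a large step of the same direction as a 170-fold higher number from compound 1 to compound 2 (2.23 log units; beyond the scatter), so in these three compounds both fluorinated phenyl groups stand far from the hex-1-yn-1-yl group, and the second fluoro group does nothing to close that gap. Nothing available accounts for either the large steps or the small one.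

The compounds shown leave open whether a group other than fluoro at this ring position, such as a methoxy group or an amine, would move the number beyond the scatter. They also leave open how much of the distance to compound 1 depends on the alkyne itself, which a shorter or longer alkynyl chain on the same aromatic carbon would address.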